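The source may report more compounds than this note shows. Statements on the series, on what has been measured and on what is new or still open speak of the compounds shown alone.

Measured so far:
compound 1, `C#CCN(CCCCOc1ccc2ccc(=O)oc2c1)Cc1ccc(C(C)C)cc1`: 35400 nM
compound 2, `C#CCN(CCCCOc1ccc2ccc(=O)oc2c1)Cc1ccc(F)c(F)c1`: 93200 nM

Among the compounds with values here, in an ADME assay on isolated protein for inhibition of Amine oxidase [flavin-containing] A (Homo sapiens), read by fluorescence and Amplex Red, with stated times of 15 min and 20 min (on this read-out higher numbers stand for weaker inhibition and lower numbers for stronger inhibition), compound 2 gives the highest of the two numbers; the only neighbor is compound 1, and the step of a 2.6-fold higher number from compound 1 to compound 2 (0.42 log units; beyond the scatter) is beyond the scatter. Compound 3, `C#CCN(C)CCCCOc1ccc2ccc(=O)oc2c1`, differs from compound 2 by hydrogen in place of 3,4-difluorophenyl on a saturated chain carbon bound to an amine nitrogen, which removes the whole aromatic portion rather than exchanging it. Within the data shown here, only the step of a 2.6-fold higher number from compound 1 to compound 2 (0.42 log units; beyond the scatter) bears on this change, and it shows that a smaller substituent on that carbon gave a higher number. Among the measured compounds shown here, compound 3 is therefore expected to move further in that direction, a 2.7-fold higher number from compound 2 to compound 3 (0.43 log units; beyond the scatter), with a wide range because no compound lacking the aryl group has yet been measured. The estimate for compound 3 is 250000 nM, between 60000 nM and 1000000 nM.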

Compound 3, half-maximal inhibitory concentration: 3280 nM
Beside the measured number, compound 3's estimate is 76-fold (1.88 log units) above it, and the stated range ends above it.
By their numbers in this assay, from the lowest: compound 3; then compound 1; then compound 2.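

In this assay, losing the aromatic ring altogether strengthens inhibition, giving a 28-fold lower number from compound 2 to compound 3 (1.45 log units; beyond the scatter) and an 11-fold lower number from compound 1 to compound 3 (1.03 log units; beyond the scatter). A ring of either kind on this saturated chain carbon bound to an amine nitrogen therefore goes with weaker inhibition than hydrogen, and the trend seen between the two rings, where the smaller substituent gave the higher number, does not extend to hydrogen. No available evidence explains this result.

As far as these compounds go, it remains open whether an ethyl group or an unsubstituted benzyl group in place of the methyl would read closer to compound 3 or to compound 1.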